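Swapping a pyridine for an oxazole on the shared core

This account rests on a few compounds, and the source may have more. Where it says the series, first, only, none or still open, it means among the compounds named here.

Compound 1, `CCCS(=O)(=O)Nc1cccc2c1CCC2c1ncc[nH]1`, gives 54% in a functional assay on CHO cells for agonist activity at Alpha-1A adrenergic receptor (Homo sapiens), read by FLIPR and calcium flux; on this read-out higher numbers stand for larger maximal responses and lower numbers for smaller maximal responses.
Compound 2, `c1cc(-c2ccn[nH]2)c2c(c1)C(c1ncc[nH]1)CC2`, gives 83% in this assay.
Compound 3, `c1cncc(-c2cccc3c2CCC3c2ncc[nH]2)c1`, gives 36% in this assay.

Compound 3 stands lowest of the three measured numbers, beyond the scatter of both others. Compound 4, `c1cc(-c2ncco2)c2c(c1)C(c1ncc[nH]1)CC2`, differs from compound 3 in one place: 1,3-oxazol-2-yl in place of pyridin-3-yl on an aromatic carbon. The 1H-pyrazol-5-yl of compound 2, like the entering 1,3-oxazol-2-yl, is a five-membered aromatic ring with two hetero atoms, so the step of a number 47 percentage points lower from compound 2 to compound 3 (beyond the scatter) bears most on this change; a number 18 percentage points lower from compound 1 to compound 3 (beyond the scatter) adds that compound 3 also sits below compound 1. An upward step partway back toward compound 2 is therefore expected for compound 4: a number 26 percentage points higher from compound 3 to compound 4 (beyond the scatter). Compound 4 is estimated at 62%, between 38% and 86%.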

Compound 4, largest response reached (Emax), in percent of the reference or control that the assay uses: 63%
Compound 4: middle estimate off by 1 percentage points, on the low side; the measured number falls inside the stated range.
By their numbers in this assay, from the lowest: compound 3; then compounds 1 and 4 (each within the scatter of the next); then compound 2.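

At this aromatic carbon, a second five-membered aromatic ring with two hetero atoms also stands above pyridin-3-yl in this assay, as a number 27 percentage points higher from compound 3 to compound 4 (beyond the scatter) shows for 1,3-oxazol-2-yl. Ring size and hetero atom count do not settle the response, since a number 20 percentage points lower from compound 2 to compound 4 (beyond the scatter) separates the two five-membered rings. The (propylsulfonyl)amino group cannot be told apart from 1,3-oxazol-2-yl, given a number 9 percentage points higher from compound 1 to compound 4 (within the scatter) for this pair. Nothing available explains why these groups differ.

Going by these compounds, whether a thiazole ring or a plain amine on this aromatic carbon would come closer to compound 2 stays open.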